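The source may report more compounds than this note shows. Statements on the series, on what has been measured and on what is new or still open speak of the compounds shown alone.

Measured compounds in a functional assay on A549 cells (Homo sapiens) for cytotoxicity, read by MTT assay, with a stated time of 72 h; on this read-out lower numbers stand for stronger inhibition and higher numbers for weaker inhibition:
compound 1, `CN(C)CCn1cnnc1-c1cc(Oc2ccc(NC(=O)N/N=C/c3c[nH]c4ccccc34)cc2F)ccn1`, gives 820 nM
compound 2, `CN(C)CCn1cnnc1-c1cc(Oc2ccc(NC(=O)N/N=C/c3ccccc3)cc2F)ccn1`, gives 1860 nM
compound 3, `CN(C)CCn1cnnc1-c1cc(Oc2ccc(NC(=O)N/N=C/c3ccc(F)cc3F)cc2F)ccn1`, gives 1870 nM

Compound 2 stands second highest of the three numbers. The step of a 1.0-fold higher number from compound 2 to compound 3 (0.00 log units; within the scatter) is within the scatter, so compound 2 and compound 3 cannot be told apart on this read-out. The step of a 2.3-fold higher number from compound 1 to compound 2 (0.36 log units; beyond the scatter) is beyond the scatter, and a 2.3-fold higher number from compound 1 to compound 3 (0.36 log units; beyond the scatter) is of the same size, so the 1H-indol-3-yl compound gives the lowest number of the three.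

Compound 4, `CN(C)CCn1cnnc1-c1cc(Oc2ccc(NC(=O)N/N=C/c3ccc(O)cc3O)cc2F)ccn1`, is not yet measured. It differs from compound 2 in one place: 2,4-dihydroxyphenyl in place of phenyl on a carbon with a double bond to nitrogen.

The step that bears on this change is the one in which the same phenyl group was exchanged on the same carbon, a 1.0-fold higher number from compound 2 to compound 3 (0.00 log units; within the scatter), which stayed within the scatter. Within the data shown here, no measured step adds hydroxyl groups to this ring, so there is no direct precedent for the two entering donors and acceptors. Among the measured compounds shown here, the only exchange that moved the number beyond the scatter, a 2.3-fold higher number from compound 1 to compound 2 (0.36 log units; beyond the scatter), involved a different ring system and does not apply here.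

The expectation is therefore no step beyond the scatter in this assay. For compound 4 the estimated value is 1700 nM, with a range from 700 nM to 4200 nM. This estimate corresponds to an expected step of a 1.1-fold lower number from compound 2 to compound 4 (0.04 log units; within the scatter).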

Compound 4, half-maximal inhibitory concentration: 12700 nM
Beside the measured number, compound 4's estimate is 7.5-fold (0.87 log units) below it, and the stated range ends below it.
By their numbers in this assay, from the lowest: compound 1; then compounds 2 and 3 (each within the scatter of the next); then compound 4.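

In this assay, the ring on the carbon with a double bond to nitrogen no longer looks indifferent to what it carries: a 6.8-fold higher number from compound 2 to compound 4 (0.83 log units; beyond the scatter) and a 6.8-fold higher number from compound 3 to compound 4 (0.83 log units; beyond the scatter) are both beyond the scatter, whereas exchanging phenyl for 2,4-difluorophenyl left compounds 2 and 3 within the scatter of each other. Among these compounds, the exchange of 1H-indol-3-yl for 2,4-dihydroxyphenyl gives a 15-fold higher number from compound 1 to compound 4 (1.19 log units; beyond the scatter) and is the only large step in the set, so this place can carry a much wider spread of numbers than the earlier compounds showed. No measurement available here accounts for the higher number of compound 4, and the data do not show how much each of the two hydroxyl groups contributes.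

The compounds shown leave open whether a single hydroxyl, as in 4-hydroxyphenyl or 2-hydroxyphenyl, is enough to raise the number or whether both are needed. Also open, from the compounds shown here alone, is where 2,4-dimethoxyphenyl or 2,4-diaminophenyl would fall on this read-out, which would show whether the higher number follows the free hydroxyl groups or any such pair of groups on the ring.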